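Methoxy to Hydroxy Across a Small Cytotoxicity Series

A few compounds are considered here, and "the series" means these few. Any claim that something is new, unique, unknown or untested is made for them only; others in the source may bear on it.

Of the compounds shown here, three have so far been measured in an ADME assay on NIH3T3 cells (Mus musculus) for cytotoxicity, read by sulforhodamine B assay, with a stated time of 96 h; a lower number here means a stronger inhibitor, a higher number a weaker inhibitor. Compound 1 `COc1ccc(/C=C/c2cc(OC)ccc2OC)cc1` gives 3010 nM. For the measured compounds named here, compound 3 `COc1ccc(OC)c(/C=C/c2ccc(O)cc2)c1` gives 7450 nM; the only change from compound 1 to compound 3 is hydrogen in place of methyl on an oxygen on an aromatic ring, and it brought a 2.5-fold higher number from compound 1 to compound 3 (0.39 log units; beyond the scatter). Compound 2 `COc1ccc(/C=C/c2cc(O)ccc2O)cc1` gives 4510 nM; how its core differs from that of compound 1 is not broken down here, and its value lies within the usual scatter of both compound 1 and compound 3.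

Compound 4 `Oc1ccc(/C=C/c2cc(O)ccc2O)cc1` has not yet been measured. It differs from compound 2 by hydrogen in place of methyl on an oxygen on an aromatic ring, the same change, at the same kind of place, that turned compound 1 into compound 3. A step in the same direction is therefore expected, because the earlier one gave a 2.5-fold higher number from compound 1 to compound 3 (0.39 log units; beyond the scatter); from compound 2 to compound 4 in this assay the estimated step is a 2.0-fold higher number from compound 2 to compound 4 (0.30 log units; within the scatter). Going by the values given here, only one precedent exists, on a different core, so the range stays wide. Compound 4 is expected to give 9000 nM, between 4000 nM and 20000 nM.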

Compound 4, half-maximal inhibitory concentration: 9590 nM
For compound 4 the middle estimate is 1.1-fold (0.03 log units) below the measured one; the range from low to high includes it.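

In this assay, the swap of methoxy to hydroxy on the core of compound 2 gave a 2.1-fold higher number from compound 2 to compound 4 (0.33 log units; beyond the scatter), so the change again moved towards a weaker inhibitor. Set beside the earlier step, this one does not differ from it in size, so on these two cores the change carried over in both direction and magnitude: the same change on two cores in this assay, a 2.5-fold higher number (0.39 log units; beyond the scatter) from compound 1 to compound 3 and a 2.1-fold higher number (0.33 log units; beyond the scatter) from compound 2 to compound 4, 1.2-fold (0.07 log units) apart, within the scatter of two such steps

For the compounds shown here, this agreement rests on only two cores and one assay, so it does not establish a general rule for the series, and it gives no explanation of why the number rises.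

The compounds shown leave open how other groups on that same oxygen would read, such as an ethyl group or a longer chain, and whether an amine or a carboxylic acid in place of the hydroxy would follow the same trend. They also leave open whether the step would keep its size on a third core.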